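A few compounds are considered here, and "the series" means these few. Any claim that something is new, unique, unknown or untested is made for them only; others in the source may bear on it.

Working notes on a series built on one shared core. Compound 1 `Cn1c(Sc2c(F)cc(C(=O)NO)cc2F)nnc1-c1cccs1` and compound 2 `Cn1c(Sc2c(F)cc(C(=O)NO)cc2F)nnc1-c1cccc(CN2CCCCCC2)c1` carry different groups on the core. In an ADME assay on a cell-free system (plasma, Rattus norvegicus) for metabolic stability, read by LC-MS, with a stated time of 4 h, tested at 100 uM (on this read-out higher numbers stand for a more stable compound and lower numbers for a less stable compound), compound 1 gives 87%, and compound 2 gives 85%; these two numbers lie within the scatter of each other, so neither stands apart. Compound 3 `Cc1cc(-c2nnc(Sc3c(F)cc(C(=O)NO)cc3F)n2C)nn1C` remains to be measured in this assay. It differs from compound 1 as follows: 1,5-dimethyl-1H-pyrazol-3-yl in place of thiophen-2-yl on an aromatic carbon. Both measured compounds retain most of the substance after the stated time. The step of a number 3 percentage points lower from compound 1 to compound 3 (within the scatter) is expected to be none beyond the scatter. Compound 3 is expected to give 84%, within 70% to 95%.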

Compound 3, percent of the compound remaining: 80%
Compound 3: the middle estimate sits 4 percentage points above what was measured; low and high end bracket the measured number.
By their numbers in this assay, from the lowest: compounds 3, 2 and 1 (each within the scatter of the next).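

In this assay the swap of thiophen-2-yl for 1,5-dimethyl-1H-pyrazol-3-yl on this aromatic carbon gives a number 7 percentage points lower from compound 1 to compound 3 (within the scatter) and thus no change beyond the scatter. This position therefore accepts a five-membered aromatic ring with 2 hetero atoms and two added methyl groups as well as the thiophene, at least on this read-out. No measurement on hand bears on the reason for this step. Still open, as far as these compounds go, is whether a carboxylic acid or a longer alkyl chain on this carbon would also stay within the scatter of compound 1.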